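Thiourea in place of a benzyl group on the shared core

The compounds below may be only part of what the source reports. "The series", "measured", "known", "first", "only" and "open" are said of these compounds alone.

Measured compounds:
compound 1 `NC(=O)c1c(NC(=O)c2ccccc2Cl)sc2c1CCN(Cc1ccccc1)C2` 14500 nM
compound 2 `NC(=O)c1c(NC(=O)c2ccccc2Cl)sc2c1CCN(Cc1ccccc1Cl)C2` 4430 nM
compound 3 `NC(=O)c1c(NC(=O)c2ccccc2Cl)sc2c1CCN(Cc1cc(Cl)cc(Cl)c1)C2` 23700 nM

Three compounds share a core and differ only in the group on the ring nitrogen. In a functional assay on MKN-74 cells (Homo sapiens) for antiproliferative activity, with a stated time of 24 h (a lower number here means a stronger inhibitor, a higher number a weaker inhibitor), compound 3 gives the highest of the three numbers; its nearest neighbour is compound 1, the step of a 1.6-fold higher number from compound 1 to compound 3 (0.21 log units; within the scatter) lying within the scatter, while the step of a 5.3-fold higher number from compound 2 to compound 3 (0.73 log units; beyond the scatter) is modest and beyond the scatter. Compound 4 `NC(=O)c1c(NC(=O)c2ccccc2Cl)sc2c1CCN(C(=S)Nc1ccccc1Br)C2` changes the same position: a group of 10 heavy atoms (7 carbon, 1 nitrogen, 1 sulfur, 1 bromine; one six-membered aromatic ring of carbon only) in place of a group of 9 heavy atoms (7 carbon, 2 chlorine; one six-membered aromatic ring of carbon only), on an amine nitrogen in a ring. The measured steps at this position, a 1.6-fold higher number from compound 1 to compound 3 (0.21 log units; within the scatter) and a 5.3-fold higher number from compound 2 to compound 3 (0.73 log units; beyond the scatter), show that exchanging one benzyl group for another moved this assay by at most a modest amount, and a 3.3-fold lower number from compound 1 to compound 2 (0.51 log units; beyond the scatter) is of similar size. Within the data shown here, no measured step involves a thiourea, so the new group is untested here; the three numbers bracket a narrow range, and compound 4 is expected to fall somewhere within or near it, with the step of a 2.0-fold lower number from compound 3 to compound 4 (0.30 log units; within the scatter) expected to be no more than modest. Compound 4 is therefore estimated at 12000 nM, in the range 3000 nM to 45000 nM.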

Compound 4, half-maximal inhibitory concentration: 10800 nM
Compound 4: the middle estimate sits 1.1-fold (0.05 log units) above what was measured; the range from low to high includes it.
By their numbers in this assay, from the lowest: compound 2; then compounds 4, 1 and 3 (each within the scatter of the next, the first and the last beyond it).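

Among these compounds, the thiourea group is the first group on this amine nitrogen in a ring that is not a benzyl group, and in this assay it does not take the compounds outside the span of the benzyl series: a 1.3-fold lower number from compound 1 to compound 4 (0.13 log units; within the scatter) lies within the scatter. Against the two chlorinated benzyl groups the steps point opposite ways, with a 2.2-fold lower number from compound 3 to compound 4 (0.34 log units; beyond the scatter) and a 2.4-fold higher number from compound 2 to compound 4 (0.39 log units; beyond the scatter) both modest, so among these compounds replacing the whole group moved the number no further than exchanging one benzyl group for another. Nothing available here explains these steps.

On these data alone, whether the bromine contributes to this reading remains open, since the thiourea appears only with that one ring. A urea with oxygen in place of the sulfur, an unsubstituted phenyl thiourea or a simple acetyl group on this nitrogen could read differently.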